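A small change on a weak inhibitor series

The compounds below may be only part of what the source reports. "The series", "measured", "known", "first", "only" and "open" are said of these compounds alone.

Of the compounds shown here, two of a shared core have been tested in a functional assay on aorta (Rattus norvegicus, strain Wister); a higher number here means a weaker inhibitor, a lower number a stronger inhibitor. Compound 1, with structure `COc1nc(-c2nc3ccccc3n2C)cc(-c2ccccc2)c1C#N`, gives 300000 nM in this assay. Compound 2, with structure `COc1nc(-c2nc3ccccc3n2C)cc(-c2ccc(Cl)cc2Cl)c1C#N`, carries a 2,4-dichlorophenyl where compound 1 carries a phenyl; in this assay compound 2 gives 214000 nM. The difference is a 1.4-fold lower number from compound 1 to compound 2 (0.15 log units; within the scatter), so the two numbers cannot be told apart, and both compounds count as weak inhibitors.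

Compound 3, with structure `COc1nc(-c2nc3ccccc3n2C)cc(-c2ccc(F)cc2)c1C#N`, is not yet measured. It differs from compound 2 in one place: 4-fluorophenyl in place of 2,4-dichlorophenyl on an aromatic carbon. For the measured compounds named here, the only measured step that bears on this position is the one from compound 1 to compound 2, and that step stayed within the scatter. Going by the values given here, nothing among the measured compounds shows that swapping one substituted phenyl for another at this carbon moves the number beyond the scatter. Compound 3 is therefore expected to sit close to compound 2, with an expected step of a 1.2-fold higher number from compound 2 to compound 3 (0.07 log units; within the scatter) in this assay. The estimated value for compound 3 is 250000 nM, with a range from 90000 nM to 700000 nM.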

Compound 3, half-maximal inhibitory concentration: 343000 nM
Estimate against measurement, compound 3: 1.4-fold (0.14 log units) below, within the range that was stated.
By their numbers in this assay, from the lowest: compounds 2, 1 and 3 (each within the scatter of the next).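

Replacing 2,4-dichlorophenyl with 4-fluorophenyl on this aromatic carbon gives a 1.6-fold higher number from compound 2 to compound 3 (0.20 log units; within the scatter) in this assay, so a second kind of substituted phenyl now sits at this position with no step beyond the scatter. Fluoro in place of hydrogen on the phenyl gives a 1.1-fold higher number from compound 1 to compound 3 (0.06 log units; within the scatter) and is also within the scatter, which means that plain phenyl, one fluorine and two chlorines cannot be told apart here, and all three compounds remain weak inhibitors in this series. No measurement among these compounds explains why the three numbers stay so close together.

Going by these compounds, these compounds change only halogens on a phenyl group, so it remains open whether an amine, a carboxylic acid or a longer chain on that phenyl, or a different group in place of the whole phenyl, would move the number beyond the scatter. On these data alone, the methoxy group and the nitrile on the shared core also remain open, since all three compounds carry them unchanged and their part in the weak inhibition cannot be read from these numbers.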